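Fluoro in place of chloro on compound 2

The source may hold more compounds than are shown below. What is called first, only, known or untested is meant among the compounds shown, and "the series" means these compounds.

Measured in an ADME assay on MT4 cells (Homo sapiens) for cytotoxicity, read by MTT assay; on this read-out higher numbers stand for lower toxicity in this test and lower numbers for higher toxicity in this test:
Compound 1 `COc1ccc(C(=O)CSc2nc(Cc3c(Cl)cccc3Cl)c(C)c(=O)[nH]2)cc1`: > 56000 nM, a limit
Compound 2 `CCc1c(Cc2c(Cl)cccc2Cl)nc(SCC(=O)c2ccc(OC)cc2)[nH]c1=O`: > 54000 nM, a limit
Compound 3 `COc1ccc(C(=O)CSc2nc(Cc3c(Cl)cccc3Cl)c(C(C)C)c(=O)[nH]2)cc1`: > 14000 nM, a limit

Compound 2 has only a limit, > 54000 nM, and the two further values shown are limits as well. The change to compound 4 `CCc1c(Cc2c(F)cccc2Cl)nc(SCC(=O)c2ccc(OC)cc2)[nH]c1=O` is fluoro in place of chloro on an aromatic carbon, turning 2,6-dichlorobenzyl into 2-chloro-6-fluorobenzyl. The measured steps are a step that the two limits leave unreadable from compound 1 to compound 2, a step that the two limits leave unreadable from compound 1 to compound 3 and a step that the two limits leave unreadable from compound 2 to compound 3. None of them touches this chloro group, so they bear on the change only loosely. In this assay no step beyond the scatter is expected, in either direction. The estimated step that the limit leaves unreadable from compound 2 to compound 4 is expected to stay small. For compound 4 the estimate is 56000 nM, expected within 20000 nM to 120000 nM.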

Compound 4, half-maximal cytotoxic concentration: > 11000 nM
Compound 4 gave a limit, no number (the forecaster's own chance of this, stated with the estimate: 75%); the middle value is on the limit's open side.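

Compound 2 and compound 4 both gave only limits, so the step between them cannot be read. The compounds shown leave open whether fluoro in place of chloro shifts the read-out in this assay at all.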